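Swapping one small ring for another on a sulfonyl-linked arm

This account rests on a few compounds, and the source may have more. Where it says the series, first, only, none or still open, it means among the compounds named here.

Compound 1 `COc1ccc(C2=NOC(c3ccc(C)cc3)C2S(=O)(=O)CC2=NCCO2)cc1`: 61.9%
Compound 2 `COc1ccc(-c2noc(-c3ccc(C)cc3)c2S(=O)(=O)CC2=NCCS2)cc1`: "not active" (no number reported)
Compound 3 `COc1ccc(C2=NOC(c3ccc(C)cc3)C2S(=O)(=O)CC2=NCCS2)cc1`: 48.6%

Three compounds were measured in a functional assay, read by Griess assay, with a stated time of 150 min, tested at 50 ug/mL; on this read-out lower numbers stand for a weaker effect and higher numbers for a stronger effect at the one concentration tested. Compound 1 gives 61.9% and compound 3 gives 48.6%; for compound 2 no single number was reported, only "not active" (no number reported).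

Compound 3 and compound 1 differ in one place only: a group of 5 heavy atoms (3 carbon, 1 nitrogen, 1 oxygen; one five-membered non-aromatic ring with 2 hetero atoms) in place of a group of 5 heavy atoms (3 carbon, 1 nitrogen, 1 sulfur; one five-membered non-aromatic ring with 2 hetero atoms), on a saturated chain carbon bound to a sulfonyl sulfur. That change produced a number 13.3 percentage points higher from compound 3 to compound 1 (beyond the scatter), a step that lies beyond the usual scatter of this read-out.

Compound 4 `COc1ccc(-c2noc(-c3ccc(C)cc3)c2S(=O)(=O)CC2=NCCO2)cc1` has not yet been measured. It stands to compound 2 as compound 1 stands to compound 3: a group of 5 heavy atoms (3 carbon, 1 nitrogen, 1 oxygen; one five-membered non-aromatic ring with 2 hetero atoms) in place of a group of 5 heavy atoms (3 carbon, 1 nitrogen, 1 sulfur; one five-membered non-aromatic ring with 2 hetero atoms), on a saturated chain carbon bound to a sulfonyl sulfur. The place line is the same word for word in both cases, so this is the same change, made on a different core. How the core of compound 2 differs from the core of compound 3 is not broken down here.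

Because the step of a number 13.3 percentage points higher from compound 3 to compound 1 (beyond the scatter) was modest, and because compound 2 gave only "not active" (no number reported), compound 4 is expected to remain weak in this assay; a gain of roughly the same size as seen from compound 3 to compound 1 would still leave it low. The estimate for compound 4 in this assay is 15%, with a range from 0% to 35%, and a real chance that again no number is reported.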

Compound 4, a percentage reported as activity, at one concentration (the size of the read-out at that concentration, not a potency): 68.8%
Compound 4: the middle estimate sits 53.8 percentage points below what was measured; the whole stated range lies below it.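

In this assay, for the compounds shown here, compound 4 gives 68.8% while compound 2 carries only the label "not active" with no number, so no step from compound 2 to compound 4 can be read. No supporting evidence bears on this result. The compounds shown leave open whether swapping the sulfur-containing ring for the oxygen-containing ring has the same effect on both cores.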